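This account rests on a few compounds, and the source may have more. Where it says the series, first, only, none or still open, it means among the compounds named here.

Working notes on a short series in a functional assay on DU-145 cells (Homo sapiens) for cytotoxicity, read by sulforhodamine B assay, with a stated time of 48 h; a lower number here means a stronger inhibitor, a higher number a weaker inhibitor. Compound 1 `C[C@H]1CC[C@@H]2[C@@H](OC(=O)[C@]23CC(c2ccc([N+](=O)[O-])cc2)=NO3)[C@]2(C)C(=O)C=C[C@@]12O` gives 7000 nM, compound 2 `C[C@H]1CC[C@@H]2[C@@H](OC(=O)[C@]23CC(c2cccc([N+](=O)[O-])c2)=NO3)[C@]2(C)C(=O)C=C[C@@]12O` gives 51000 nM, and compound 3 `C[C@H]1CC[C@@H]2[C@@H](OC(=O)[C@]23CC(c2ccc(F)cc2)=NO3)[C@]2(C)C(=O)C=C[C@@]12O` gives 13000 nM. Compound 3 holds the second highest of the three numbers, but only by rank: a 1.9-fold higher number from compound 1 to compound 3 (0.27 log units; within the scatter) lies within the scatter, so those two values are not separated. By contrast, a 3.9-fold lower number from compound 2 to compound 3 (0.59 log units; beyond the scatter) lies beyond the scatter and is modest in size.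

Compound 4 `C[C@H]1CC[C@@H]2[C@@H](OC(=O)[C@]23CC(c2ccc(C#N)cc2)=NO3)[C@]2(C)C(=O)C=C[C@@]12O` differs from compound 3 by cyano in place of fluoro on an aromatic carbon. In words, this is cyano in place of fluoro on an aromatic carbon, para to a large group.

For the measured compounds named here, the nearest measured precedent is a 1.9-fold higher number from compound 1 to compound 3 (0.27 log units; within the scatter), the only measured exchange of one group for another at this place on the 4-substituted phenyl, and it stayed within the scatter. The modest 7.3-fold higher number from compound 1 to compound 2 (0.86 log units; beyond the scatter) moves the nitro group to another ring position, which the present change does not do, so it bears on this step only weakly. No step beyond the scatter is therefore expected in this assay. The expected change is a 1.3-fold lower number from compound 3 to compound 4 (0.11 log units; within the scatter), which is small. The estimated value for compound 4 is 10000 nM, with an expected range of 4000 nM to 25000 nM.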

Compound 4, half-maximal inhibitory concentration: 26000 nM
The estimate for compound 4 lay 2.6-fold (0.41 log units) below the measured number; measured number outside the range, above it.
By their numbers in this assay, from the lowest: compounds 1, 3, 4 and 2 (each within the scatter of the next, the first and the last beyond it).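

In this assay, for the compounds shown here, cyano in place of nitro on the aromatic carbon gives the first exchange of one group for another at this place that lies beyond the scatter, a 3.7-fold higher number from compound 1 to compound 4 (0.57 log units; beyond the scatter), a modest step, whereas fluoro in place of nitro stayed within it at a 1.9-fold higher number from compound 1 to compound 3 (0.27 log units; within the scatter). The two replacements of nitro are not separated from each other, at a 2.0-fold higher number from compound 3 to compound 4 (0.30 log units; within the scatter), so these data give no order for cyano and fluoro at this place. Going by these compounds alone, the 4-cyanophenyl group is also not separated from the 3-nitrophenyl group, at a 2.0-fold lower number from compound 2 to compound 4 (0.29 log units; within the scatter), so the effect of exchanging 4-nitrophenyl is no longer seen only in the modest 7.3-fold higher number from compound 1 to compound 2 (0.86 log units; beyond the scatter).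

No evidence beyond the cell numbers bears on these steps, and what lies behind them remains unknown. Open, as far as these compounds go, is whether an amine or a carboxylic acid on the same aromatic carbon would give a number near that of compound 1, or one not separated from those of compound 3 and compound 4.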